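The compounds below may be only part of what the source reports. "The series", "measured", "known", "first", "only" and "open" are said of these compounds alone.

Compound 1, whose structure is `CC(C)C(=O)OCOC(=O)C1=C(S[C@@H]2CN[C@H](C(=O)Nc3cccc(C(=O)O)c3)C2)[C@H](C)[C@@H]2[C@@H]([C@@H](C)O)C(=O)N12`, was tested in a physicochemical assay for metabolic stability, read by LC-MS, in phosphate buffer, with a stated time of 3 h, at pH 7.4, tested at 50 uM; on this read-out lower numbers stand for a less stable compound and higher numbers for a more stable compound. There compound 1 reaches > 95%, which is a limit of the assay rather than a number. Two related compounds were run alongside it. Compound 2, with structure `CC(C)C(=O)OCOC(=O)C1=C(S[C@@H]2CN[C@H](C(=O)Nc3cccc(C(=O)OCOC(=O)C(C)C)c3)C2)[C@H](C)[C@@H]2[C@@H]([C@@H](C)O)C(=O)N12`, carries a second ((isopropylcarbonyl)oxy)methyl group in place of hydrogen on an oxygen next to a carbonyl group, and in this assay compound 2 also reaches > 95%, again a limit. Compound 3, with structure `CCOC(=O)C1=C(S[C@H]2C[C@@H](C(=O)Nc3cccc(C(=O)OCC)c3)N(Cc3oc(=O)oc3C)C2)[C@H](C)[C@@H]2[C@@H]([C@@H](C)O)C(=O)N12`, gives > 95% in this assay, likewise a limit. Within the data shown here, because all three sit at the limit of > 95% in this assay, at which 3 of the 3 values shown sit, the one computed step, a step that the two limits leave unreadable from compound 1 to compound 2, cannot be read, and compound 1 can only be placed at that limit together with the other two.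

Compound 4, whose structure is `COC(=O)OCOC(=O)C1=C(S[C@@H]2CN[C@H](C(=O)Nc3cccc(C(=O)O)c3)C2)[C@H](C)[C@@H]2[C@@H]([C@@H](C)O)C(=O)N12`, differs from compound 1 by methoxy in place of isopropyl on a carbonyl carbon. Among the measured compounds shown here, no measured step speaks to this change, since the only one available is hidden by the limit. The expectation for the step from compound 1 to compound 4 in this assay is therefore a number at least 2 percentage points lower from compound 1 to compound 4 (that floor lies within the scatter), that is, no change beyond the scatter. For compound 4 the estimate in this assay is 93%, with a range from 80% to 99%.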

Compound 4, percent of the compound remaining: > 95%
Compound 4 ended at the assay's limit (the forecaster's own chance of this, stated with the estimate: 60%); at least 2 percentage points between middle value and limit.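

The step from compound 1 to compound 4 cannot be read, because both compounds sit at the same limit, which is not a number: the limit of > 95% in this assay, at which 4 of the 4 values shown sit.

The compounds shown leave open whether methoxy in place of isopropyl on a carbonyl carbon changes the percent of compound remaining at all, and how compound 1, compound 2, compound 3 and compound 4 would rank against each other.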